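A few compounds are considered here, and "the series" means these few. Any claim that something is new, unique, unknown or untested is made for them only; others in the source may bear on it.

Working notes on the series. For the measured compounds named here, the three compounds measured so far share one core and differ only in the aryl group on the amide carbonyl. Compound 1 `COc1ccc(C(=O)NC[C@H]2c3[nH]c4ccccc4c3C[C@H]3[C@H]4c5[nH]c6ccccc6c5C[C@@H]([C@H](C#N)N23)N4C)cc1` carries a 4-methoxyphenyl amide and gives 430 nM in a functional assay on HCT-116 cells (Homo sapiens) for cytotoxicity, read by MTT assay, with a stated time of 72 h; on this read-out lower numbers stand for stronger inhibition and higher numbers for weaker inhibition. Compound 2 `CCc1ccc(C(=O)NC[C@H]2c3[nH]c4ccccc4c3C[C@H]3[C@H]4c5[nH]c6ccccc6c5C[C@@H]([C@H](C#N)N23)N4C)cc1` carries a 4-ethylphenyl amide and gives 100 nM; the step of a 4.3-fold lower number from compound 1 to compound 2 (0.63 log units; beyond the scatter) is the only one here beyond the scatter on the measured side. Compound 3 `CN1[C@@H]2c3[nH]c4ccccc4c3C[C@H]1[C@H](C#N)N1[C@@H](CNC(=O)c3ccc4ccccc4c3)c3[nH]c4ccccc4c3C[C@@H]21` carries a naphthalen-2-yl amide and gives 420 nM, which sits second highest of the three numbers, within the scatter of compound 1 (a 1.0-fold lower number from compound 1 to compound 3 (0.01 log units; within the scatter)) and a modest distance from compound 2 (a 4.2-fold higher number from compound 2 to compound 3 (0.62 log units; beyond the scatter)).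

Compound 4 `CN1[C@@H]2c3[nH]c4ccccc4c3C[C@H]1[C@H](C#N)N1[C@@H](CNC(=O)c3ccc4ccccc4n3)c3[nH]c4ccccc4c3C[C@@H]21` is not yet measured. Its difference from compound 3 is quinolin-2-yl in place of naphthalen-2-yl on a carbonyl carbon. Going by the values given here, no measured step swaps an aromatic carbon for a ring nitrogen in this aryl group, so the bearing steps are only the aryl-amide exchanges above: one within the scatter, one modest. For compound 4 the expected step is therefore a 1.1-fold lower number from compound 3 to compound 4 (0.02 log units; within the scatter), that is none beyond the scatter, and the expected value for compound 4 is 400 nM, with a range from 150 nM to 1200 nM.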

Compound 4, half-maximal inhibitory concentration: 240 nM
Compound 4: middle estimate off by 1.7-fold (0.22 log units), on the high side; the measured number falls inside the stated range.
By their numbers in this assay, from the lowest: compound 2; then compounds 4, 3 and 1 (each within the scatter of the next).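

In this assay, for the compounds shown here, quinolin-2-yl in place of naphthalen-2-yl on the carbonyl carbon gives a 1.8-fold lower number from compound 3 to compound 4 (0.24 log units; within the scatter), so at this position a ring nitrogen in the bicyclic aryl group, with its one hydrogen-bond acceptor by count, produces no step that can be read. Against the monocyclic amides, a 1.8-fold lower number from compound 1 to compound 4 (0.25 log units; within the scatter) also stays inside the scatter, whereas a 2.4-fold higher number from compound 2 to compound 4 (0.38 log units; beyond the scatter) lies beyond it, leaving the 4-ethylphenyl amide of compound 2 apart from the other three compounds. Nothing at hand accounts for these results.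

Open, from the compounds shown here alone, is whether a smaller nitrogen-bearing aryl group, such as pyridin-2-yl, would match the quinolin-2-yl amide of compound 4. Also open, going by these compounds, is whether a longer chain, as in 4-propylphenyl, or an amine, as in 4-aminophenyl, would hold the number of compound 2.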